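The source may report more compounds than this note shows. Statements on the series, on what has been measured and on what is new or still open speak of the compounds shown alone.

Two compounds have been measured so far in a functional assay for inhibition, read by spectrophotometry, with a stated time of 20 min, tested at 2 mg/mL; a higher number here means a stronger effect of the compound at the concentration tested, a lower number a weaker effect:

Compound 1, `CC(=O)c1ccc(NC(=O)C2CC(O)CN2S(=O)(=O)c2ccc(C)cc2)cc1`, gives 12.5%.
Compound 2, `CC(=O)c1ccc(NC(=O)C2CC(O)CN2S(=O)(=O)c2ccc([N+](=O)[O-])cc2)cc1`, gives 57%.

Among the compounds with values here, compound 2 stands highest of the two numbers; its nearest neighbour, compound 1, lies clearly lower, and the only measured step, a number 44.5 percentage points higher from compound 1 to compound 2 (beyond the scatter), is large and beyond the scatter. The next compound, compound 3, `CC(=O)c1ccc(NC(=O)C2CC(O)CN2S(=O)(=O)c2ccccc2)cc1`, is not yet measured. It differs from compound 2 by hydrogen in place of nitro on an aromatic carbon. Within the data shown here, this change is the near reverse of the single measured step: where replacing methyl with nitro on the same aromatic carbon raised inhibition by a number 44.5 percentage points higher from compound 1 to compound 2 (beyond the scatter), removing nitro should give most of that gain back. Compound 3 is therefore expected to fall well below compound 2, by about a number 37 percentage points lower from compound 2 to compound 3 (beyond the scatter) in this assay. The estimate for compound 3 is 20%, with a range from 5% to 40%.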

Compound 3, a percentage reported as inhibition, at one concentration (the size of the read-out at that concentration, not a potency): 45%
The estimate for compound 3 lay 25 percentage points below the measured number, outside the stated range (above it).
By their numbers in this assay, from the lowest: compound 1; then compound 3; then compound 2.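

In this assay, the change from 4-nitrophenyl to phenyl gives up only a modest part of the inhibition (a number 12 percentage points lower from compound 2 to compound 3 (beyond the scatter)), while hydrogen in place of methyl brings a large rise (a number 32.5 percentage points higher from compound 1 to compound 3 (beyond the scatter)). So the earlier jump from compound 1 to compound 2 was not mainly a matter of adding nitro: most of that gap already opens when the methyl goes, and nitro adds a smaller further step on top of hydrogen. Nothing available explains why the three groups fall in this order.

Hydrogen, methyl and nitro are only three points at this one place on the ring, so it remains open whether methyl is an isolated low point or part of a wider trend. An amine, a carboxylic acid or a chlorine atom at the same place would show where other groups fall relative to compound 2 and compound 3.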